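Swapping carboxy for bromo on the benzylamine ring

The compounds below may be only part of what the source reports. "The series", "measured", "known", "first", "only" and "open" are said of these compounds alone.

Measured compounds:
compound 1 `Oc1ccc(CNc2cc(C(F)(F)F)cc3[nH]ncc23)cc1` — 81%
compound 2 `O=C(O)c1cccc(CNc2cc(C(F)(F)F)cc3[nH]ncc23)c1` — 17%

Two compounds sharing one core were tested in an assay for inhibition of Indoleamine 2,3-dioxygenase 1 (Homo sapiens), with stated times of 10 min and 60 min, tested at 100 uM; on this read-out higher numbers stand for a stronger effect at the one concentration tested and lower numbers for a weaker effect. Compound 1 `Oc1ccc(CNc2cc(C(F)(F)F)cc3[nH]ncc23)cc1` gives 81%, while compound 2 `O=C(O)c1cccc(CNc2cc(C(F)(F)F)cc3[nH]ncc23)c1` gives 17%, the lowest of the two numbers and well beyond the usual scatter from compound 1. Whatever is on this aromatic ring therefore matters a great deal for the read-out.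

Compound 3 `FC(F)(F)c1cc(NCc2cccc(Br)c2)c2cn[nH]c2c1` has not yet been measured in this assay. It differs from compound 2 in one place: bromo in place of carboxy on an aromatic carbon. The carboxy group leaves entirely, and a single bromine atom takes its spot on the same aromatic carbon.

Among the measured compounds shown here, no direct step for this change has been measured, so the expectation leans on the two known numbers. Compound 2 with carboxy sits at 17%, whereas compound 1 with a hydroxy group on the same ring reaches 81%. Removing carboxy is expected to move the number upward, with the step from a number 38 percentage points higher from compound 2 to compound 3 (beyond the scatter) estimated to lie beyond the scatter. Compound 3 is therefore expected to give about 55%, within a range of 25% to 85%.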

Compound 3, a percentage reported as inhibition, at one concentration (the size of the read-out at that concentration, not a potency): 51%
The estimate for compound 3 lay 4 percentage points above the measured number; the range from low to high includes it.
By their numbers in this assay, from the lowest: compound 2; then compound 3; then compound 1.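

In this assay, bromo in place of carboxy on this aromatic carbon gives a number 34 percentage points higher from compound 2 to compound 3 (beyond the scatter), so the position can hold a group with no hydrogen-bond donor or acceptor, and the low number of the carboxy compound does not apply to every group placed there. The other new comparison, 3-bromophenyl in place of 4-hydroxyphenyl, gives a number 30 percentage points lower from compound 1 to compound 3 (beyond the scatter), which shows that bromo at this position does not match the hydroxy-bearing ring, although this step changes both the group and where it sits on the ring, so neither alone can be held responsible. Nothing measured here explains why these groups give such different numbers.

The compounds shown leave open whether the gap on the hydroxy side comes from the group or from its place, a question that a hydroxy group on the carbon now holding bromo could address. They also leave open how an amine, a methyl group or a chlorine atom on that same carbon would read out, and so whether bromo is special or just one of many groups that give a number well above that of the carboxy compound.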